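The source may report more compounds than this note shows. Statements on the series, on what has been measured and on what is new or still open speak of the compounds shown alone.

Three compounds have so far been measured in an assay on CHO cells for displacement of a labelled ligand from melanin-concentrating hormone receptor 1 (Homo sapiens), read by scintillation counting, with a stated time of 1 h; on this read-out lower numbers stand for stronger inhibition and higher numbers for weaker inhibition:

compound 1 `Cn1c(C2CC2)nc2ccc(-n3ccc(OCc4ccc(Cl)cc4)cc3=O)cc21` gives 35 nM;
compound 2 `Cn1c(C2CC2)nc2ccc(-n3ccc(OCc4ccc(F)cc4)cc3=O)cc21` gives 40 nM;
compound 3 `Cn1c(CC2CC2)nc2ccc(-n3ccc(OCc4ccc(F)cc4)cc3=O)cc21` gives 90 nM.

Compound 1 has the lowest of the three values. Compound 2 is nearest to it, with a 1.1-fold higher number from compound 1 to compound 2 (0.06 log units; within the scatter), a difference too small to separate the two. Compound 3 lies furthest away, and its gap from compound 1 is beyond the scatter, so compound 1 does stand apart from compound 3.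

Compound 4 `CCn1c(C2CC2)nc2ccc(-n3ccc(OCc4ccc(Cl)cc4)cc3=O)cc21` has not yet been measured. It differs from compound 1 by methyl in place of hydrogen on a saturated chain carbon bound to an aromatic nitrogen. Going by the values given here, no measured step touches this position, so the expectation rests on the closest comparison available: the step of a 2.3-fold higher number from compound 2 to compound 3 (0.35 log units; beyond the scatter), the only measured change that lengthens a carbon group, raised the number modestly. By analogy, adding a methyl in compound 4 is expected to give no more than a small rise in this assay, quite possibly one that stays within the scatter. Compound 4 is therefore expected to give about 50 nM, with a likely range from 20 nM to 130 nM. For compound 4 this estimate means an expected step of a 1.4-fold higher number from compound 1 to compound 4 (0.15 log units; within the scatter).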

Compound 4, half-maximal inhibitory concentration: 37 nM
Beside the measured number, compound 4's estimate is 1.4-fold (0.13 log units) above it; the measured number falls inside the stated range.
By their numbers in this assay, from the lowest: compounds 1, 4 and 2 (each within the scatter of the next); then compound 3.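

Until now every measured compound carried the same methyl group on the aromatic nitrogen, so nothing showed whether this part of the molecule could be varied at all. Compound 4 gives the first reading: methyl in place of hydrogen on a saturated chain carbon bound to an aromatic nitrogen, which turns methyl into ethyl, produces a 1.1-fold higher number from compound 1 to compound 4 (0.02 log units; within the scatter), so in this assay the two compounds cannot be told apart. Going by these compounds alone, that differs from the only other step that lengthens a carbon group, a 2.3-fold higher number from compound 2 to compound 3 (0.35 log units; beyond the scatter), which sits at another place on the core and lies beyond the scatter; no measured explanation for this contrast is available here.

The compounds shown leave open how far this position can be extended, since a single added methyl says little about a longer chain such as propyl, a branched group such as isopropyl, or a chain ending in an amine or a carboxylic acid. Going by these compounds, it also remains unknown whether ethyl would behave the same way with fluoro in place of chloro, or with cyclopropylmethyl in place of cyclopropyl.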